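Amide aryl variation in a shared-core antiproliferative series

This account rests on a few compounds, and the source may have more. Where it says the series, first, only, none or still open, it means among the compounds named here.

Measured compounds:
compound 1 `COc1ccc(C(=O)Nc2cccc(-c3oc4cc(-c5ccc(F)cc5)ccc4c(=O)c3O)c2)cc1` — 6250 nM
compound 2 `O=C(Nc1cccc(-c2oc3cc(-c4ccc(F)cc4)ccc3c(=O)c2O)c1)c1ccc(Cl)cc1` — 4730 nM
compound 3 `COc1ccccc1C(=O)Nc1cccc(-c2oc3cc(-c4ccc(F)cc4)ccc3c(=O)c2O)c1` — 2100 nM

In a functional assay on MCF7 cells (Homo sapiens) for antiproliferative activity, read by CCK-8 assay, with a stated time of 72 h (a higher number here means a weaker inhibitor, a lower number a stronger inhibitor), compound 2 gives 4730 nM, the second highest of the three numbers. The nearest number lies in the step of a 1.3-fold lower number from compound 1 to compound 2 (0.12 log units; within the scatter); the furthest in the step of a 2.3-fold lower number from compound 2 to compound 3 (0.35 log units; beyond the scatter).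

Compound 4 `COc1cccc(C(=O)Nc2cccc(-c3oc4cc(-c5ccc(F)cc5)ccc4c(=O)c3O)c2)c1` differs from compound 2 in one place: 3-methoxyphenyl in place of 4-chlorophenyl on a carbonyl carbon. Going by the values given here, two measured steps bear on it. Swapping chloro for methoxy on the aromatic carbon gave a 1.3-fold lower number from compound 1 to compound 2 (0.12 log units; within the scatter), so the halogen-to-methoxy part alone carries little. Moving the methoxy to the 2-position gave a 3.0-fold lower number from compound 1 to compound 3 (0.47 log units; beyond the scatter) and a 2.3-fold lower number from compound 2 to compound 3 (0.35 log units; beyond the scatter), both modest. The 3-methoxyphenyl is neither measured position, so a small step toward a lower number is expected, a 1.4-fold lower number from compound 2 to compound 4 (0.13 log units; within the scatter). Compound 4 is estimated at 3500 nM, in the range 1500 nM to 8000 nM in this assay.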

Compound 4, half-maximal inhibitory concentration: 15300 nM
Compound 4: the middle estimate sits 4.4-fold (0.64 log units) below what was measured; the measured number lies above the stated range.
By their numbers in this assay, from the lowest: compound 3; then compounds 2 and 1 (each within the scatter of the next); then compound 4.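

In this assay the methoxy isomers separate widely, with a 7.3-fold higher number from compound 3 to compound 4 (0.86 log units; beyond the scatter) and a 2.4-fold higher number from compound 1 to compound 4 (0.39 log units; beyond the scatter), so compound 4 carries the highest number of the three and the 3-methoxyphenyl does not fall between the other two. Replacing the 4-chlorophenyl also costs activity, with a 3.2-fold higher number from compound 2 to compound 4 (0.51 log units; beyond the scatter), although the earlier chloro and methoxy pair showed no such separation. No available evidence accounts for this ordering.

Open, from the compounds shown here alone, is whether the rise is specific to methoxy, or also appears with an amine or a carboxylic acid on that phenyl ring. Also open, going by these compounds, is whether 3-chlorophenyl and 2-chlorophenyl would follow their methoxy counterparts.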